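Swapping the ring on the aromatic nitrogen

The source may report more compounds than this note shows. Statements on the series, on what has been measured and on what is new or still open speak of the compounds shown alone.

The measured compounds and their values:
compound 1 `COc1cc2ncnc(Nc3ccc(F)c(Cl)c3)c2cc1OCCCCC(=O)Nc1ccc(S(N)(=O)=O)cc1` gives 5020 nM in a functional assay on A-431 cells (Homo sapiens) for antiproliferative activity, read by MTT assay, with a stated time of 72 h; a lower number here means a stronger inhibitor, a higher number a weaker inhibitor;
compound 2 `COc1cc2ncnc(Nc3ccc(Cl)cc3)c2cc1OCCCCC(=O)Nc1ccc(S(N)(=O)=O)cc1` gives 7120 nM in this assay;
compound 3 `COc1ccc(Nc2ncnc3cc(OC)c(OCCCCC(=O)Nc4ccc(S(N)(=O)=O)cc4)cc23)cc1OC` gives 35400 nM in this assay.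

Compound 3 has the highest number of the three, so it is the weakest inhibitor shown. Its nearest neighbour is compound 2, with a 5.0-fold higher number from compound 2 to compound 3 (0.70 log units; beyond the scatter); compound 1 lies further away, with a 7.1-fold higher number from compound 1 to compound 3 (0.85 log units; beyond the scatter). Compound 1 and compound 2 differ from each other by a 1.4-fold higher number from compound 1 to compound 2 (0.15 log units; within the scatter), so those two cannot be told apart on these numbers.

Compound 4 `CCc1ccc(Nc2ncnc3cc(OC)c(OCCCCC(=O)Nc4ccc(S(N)(=O)=O)cc4)cc23)cc1` is the next step from compound 3: 4-ethylphenyl in place of 3,4-dimethoxyphenyl on a nitrogen on an aromatic ring.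

The two steps that bear on this are those leading into compound 3: both replaced a ring that carried no oxygen with the 3,4-dimethoxyphenyl group, and both raised the number by a modest amount, beyond the scatter. The change to compound 4 removes the 3,4-dimethoxyphenyl group again, returning to a ring without acceptors, as in compound 1 and compound 2. The expectation in this assay is therefore a lower number, of a size near those two steps, so that compound 4 is expected to land close to compound 1 and compound 2; this means an expected step of a 5.1-fold lower number from compound 3 to compound 4 (0.70 log units; beyond the scatter). Compound 4 is thus estimated at 7000 nM, with a range from 2500 nM to 25000 nM.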

Compound 4, half-maximal inhibitory concentration: 7220 nM
The estimate for compound 4 lay 1.0-fold (0.01 log units) below the measured number; measured number inside the range.
By their numbers in this assay, from the lowest: compounds 1, 2 and 4 (each within the scatter of the next); then compound 3.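

In this assay, 4-ethylphenyl in place of 3,4-dimethoxyphenyl gives a 4.9-fold lower number from compound 3 to compound 4 (0.69 log units; beyond the scatter) on the same core, so the gap seen at compound 3 closes once those two oxygens are gone. Compound 4 shows that the earlier match between compound 1 and compound 2 does not depend on halogens on the ring: ethyl in place of chloro gives a 1.0-fold higher number from compound 2 to compound 4 (0.01 log units; within the scatter) and 4-ethylphenyl in place of 3-chloro-4-fluorophenyl gives a 1.4-fold higher number from compound 1 to compound 4 (0.16 log units; within the scatter) on this same nitrogen. Among these four compounds, then, only the 3,4-dimethoxyphenyl ring stands apart, while chloro, chloro with fluoro, and ethyl cannot be told apart in this read-out. No measurement in hand explains why the 3,4-dimethoxyphenyl ring gives the higher number.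

On these data alone, whether both methoxy groups are needed for that higher number remains open, and a ring with a single methoxy would address it. As far as these compounds go, how far the ring tolerates other groups also remains open, for example an amine, a carboxylic acid or a carbon chain longer than ethyl.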